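This account rests on a few compounds, and the source may have more. Where it says the series, first, only, none or still open, it means among the compounds named here.

Among the compounds with values here, compound 1 `CN[C@@H]1CCN(c2c(F)cc3c(=O)c(C(=O)O)cn(Cc4ccc(-c5ccccc5)cc4)c3c2OC)C1` and compound 2 `COc1c(N2CC[C@@H](C(N)=O)C2)c(F)cc2c(=O)c(C(=O)O)cn(Cc3ccc(-c4ccccc4)cc3)c12` share one core and are the two measured members of this set. In an assay on isolated protein for inhibition of DNA topoisomerase 1 (Homo sapiens), with a stated time of 15 min (on this read-out higher numbers stand for weaker inhibition and lower numbers for stronger inhibition), compound 1 gives 57700 nM. Compound 2 reaches only a limit of the measurement, > 200000 nM, a limit at which compound 2 sits (the limit of > 200000 nM in this assay, at which 1 of the 2 values shown sits). Within the data shown here, the step of an at least 3.4-fold higher number from compound 1 to compound 2 (0.53 log units; beyond the scatter) is the single measured step. Compound 3 `COc1c(NCCN)c(F)cc2c(=O)c(C(=O)O)cn(Cc3ccc(-c4ccccc4)cc3)c12` differs from compound 2 by (2-aminoethyl)amino in place of 3-carbamoylpyrrolidin-1-yl on an aromatic carbon. Among the measured compounds shown here, no measured step covers this change, and compound 2 itself is only a limit, so the expectation is loose. Compound 3 is estimated to give 100000 nM, ranging from 30000 nM to 400000 nM, an expected step of an at least 2.0-fold lower number from compound 2 to compound 3 (0.30 log units; that floor lies within the scatter).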

Compound 3, half-maximal inhibitory concentration: > 200000 nM
Compound 3 gave a limit, no number; the forecaster's own chance of this, stated with the estimate: 35%; middle value at least 2.0-fold (0.30 log units) away from the limit.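

Replacing the ring with an open chain on this aromatic carbon also weakens inhibition: in this assay, (2-aminoethyl)amino in place of 3-(methylamino)pyrrolidin-1-yl gives an at least 3.4-fold higher number from compound 1 to compound 3 (0.53 log units; beyond the scatter). Of the three groups shown at this position, only 3-(methylamino)pyrrolidin-1-yl gives a number rather than a limit, so carrying an amine does not alone preserve a measurable value. The step between compound 2 and compound 3 cannot be read because both values are limits: the limit of > 200000 nM in this assay, at which 2 of the 3 values shown sit.

Still open, on these data alone, is whether the pyrrolidine ring, its methylamino group or both matter for compound 1. A 3-aminopyrrolidin-1-yl group or a longer chain such as (3-aminopropyl)amino would help separate these possibilities.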